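Swapping the benzylic aryl group in a sulfonamide series

The source may hold more compounds than are shown below. What is called first, only, known or untested is meant among the compounds shown, and "the series" means these compounds.

Compounds measured so far in a functional assay on MIA PaCa-2 cells (Homo sapiens) for inhibition, read by MTT assay, with a stated time of 72 h; a higher number here means a weaker inhibitor of growth, a lower number a stronger inhibitor of growth:
- compound 1 `O=S(=O)(NCCNCc1ccc(-c2ccccc2)cc1)c1cc(C(F)(F)F)cc(C(F)(F)F)c1`: 2700 nM
- compound 2 `O=S(=O)(NCCCNCc1ccc(Cl)c(C(F)(F)F)c1)c1cc(C(F)(F)F)cc(C(F)(F)F)c1`: 7400 nM
- compound 3 `O=S(=O)(NCCCCCCNCc1ccc(Br)cc1)c1ccc(C(F)(F)F)cc1`: 3830 nM

Compound 2 sits at the high end of these three numbers. Its gap to compound 3 is within the scatter of repeated measurements, while its gap to compound 1 is beyond it, so only compound 1 can be said to inhibit growth more strongly than compound 2.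

Compound 4 `O=S(=O)(NCCCNCc1ccc(Br)cc1)c1cc(C(F)(F)F)cc(C(F)(F)F)c1` has not yet been measured. It differs from compound 2 by 4-bromophenyl in place of 4-chloro-3-(trifluoromethyl)phenyl on a saturated chain carbon bound to an amine nitrogen. Going by the values given here, no measured pair isolates this change, so no step is known for it. The expected step from compound 2 to compound 4 is a 1.3-fold lower number from compound 2 to compound 4 (0.13 log units; within the scatter), a change that is not expected to go beyond the scatter. For compound 4 the estimate in this assay is 5500 nM, with a range from 2200 nM to 14000 nM.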

Compound 4, concentration for 50% growth inhibition: 2300 nM
Compound 4: middle estimate off by 2.4-fold (0.38 log units), on the high side, within the range that was stated.
By their numbers in this assay, from the lowest: compounds 4, 1, 3 and 2 (each within the scatter of the next, the first and the last beyond it).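

Going by these compounds alone, this is the first pair that differs in one place, and it shows that the aryl group on this saturated chain carbon matters: in this assay, 4-bromophenyl in place of 4-chloro-3-(trifluoromethyl)phenyl gives a 3.2-fold lower number from compound 2 to compound 4 (0.51 log units; beyond the scatter), a step larger than the estimate foresaw. Nothing available explains why this swap strengthens growth inhibition.

Still open, from the compounds shown here alone, is whether the step comes from gaining the bromine or from losing the chlorine and trifluoromethyl group. A plain phenyl group here, or the same swap on a longer chain, would help to answer that.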